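Hydroxy addition carried over to a second core

This account rests on a few compounds, and the source may have more. Where it says the series, first, only, none or still open, it means among the compounds named here.

Compound 1 `COc1ccc(-c2coc(=O)n2-c2cc(OC)c(OC)c(OC)c2)cc1` and compound 3 `COc1ccc(-c2oc(O)nc2-c2cc(OC)c(OC)c(OC)c2)cc1` are built from the same atoms joined differently; the difference between the two cores is not broken down here. In a functional assay on PC-3 cells (Homo sapiens) for inhibition (a higher number here means a weaker inhibitor, a lower number a stronger inhibitor), compound 1 gives 7.5 nM and compound 3 gives 20.1 nM, so compound 3 stands highest of the three measured numbers. Compound 2 `COc1ccc(-c2coc(=O)n2-c2cc(OC)c(OC)c(OC)c2)cc1O` differs from compound 1 by hydroxy in place of hydrogen on an aromatic carbon, and in this assay compound 2 gives 2.3 nM; this amounts to a 3.3-fold lower number from compound 1 to compound 2 (0.51 log units; beyond the scatter). Compound 4 `COc1ccc(-c2oc(O)nc2-c2cc(OC)c(OC)c(OC)c2)cc1O` is not yet measured; it differs from compound 3 by hydroxy in place of hydrogen on an aromatic carbon, the same change as before, with the same surroundings around the place, now made on the core of compound 3. The step expected from compound 3 to compound 4 in this assay is a 3.1-fold lower number from compound 3 to compound 4 (0.49 log units; beyond the scatter), set beside a 3.3-fold lower number from compound 1 to compound 2 (0.51 log units; beyond the scatter), resting on that single measured instance of the change and on compound 1 and compound 3 sharing their atoms. With that expectation compound 4 is estimated at 6.5 nM, with a range from 2.5 nM to 17 nM.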

Compound 4, half-maximal inhibitory concentration: 6.4 nM
Compound 4: middle estimate off by 1.0-fold (0.01 log units), on the high side, within the range that was stated.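

In this assay, the change from 4-methoxyphenyl to 3-hydroxy-4-methoxyphenyl on the second core gives a 3.1-fold lower number from compound 3 to compound 4 (0.50 log units; beyond the scatter). Within this series, the size of the step carries over from one core to the other: the same change on two cores in this assay, a 3.3-fold lower number (0.51 log units; beyond the scatter) from compound 1 to compound 2 and a 3.1-fold lower number (0.50 log units; beyond the scatter) from compound 3 to compound 4, 1.0-fold (0.02 log units) apart, within the scatter of two such steps. This agreement rests on one pair of compounds per core, a single place on the aromatic ring and a single assay, so it does not show that the step would hold on any further core, nor does it explain why the hydroxy group lowers the number or why the two cores stand apart.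

The compounds shown leave open whether an amine or a fluorine at the same place on the aromatic ring would also give steps of matching size on the two cores. Also open, on these data alone, is whether the hydroxy step would keep its size with a longer chain, such as ethoxy, in place of the methoxy of the 4-methoxyphenyl group.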